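The source may hold more compounds than are shown below. What is called first, only, known or untested is meant among the compounds shown, and "the series" means these compounds.

Compound 1, `O=C(COc1c(F)cc(C(=O)c2ccc(F)cc2)cc1Cl)NNC(=O)c1ccc(=O)oc1`, was examined in a functional assay on HeLa cells (Homo sapiens) for cytotoxicity, read by trypan blue exclusion, with a stated time of 48 h (on this read-out higher numbers stand for weaker inhibition and lower numbers for stronger inhibition), and in that assay compound 1 gives 59200 nM. Its only companion among the measured compounds is compound 2, `O=C(COc1ccc(C(=O)c2ccccc2)cc1)NNC(=O)c1ccc(=O)oc1`, which in this assay gives 89200 nM. The two numbers sit within the usual scatter of each other, so on the evidence shown compound 1 and compound 2 cannot be told apart, and no ordering between them can be claimed.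

The step of interest leads from compound 1 to compound 3, `O=C(COc1c(F)cc(C(=O)c2ccc(Cl)cc2)cc1Cl)NNC(=O)c1ccc(=O)oc1`, which has not yet been measured in this assay. The change is small: chloro in place of fluoro on an aromatic carbon. Nothing in the measured pair speaks to what such an exchange does on this read-out, since compound 2 differs from compound 1 in several places at once. With one halogen swapped for another on the same aromatic carbon and no other alteration, the expected step is none beyond the scatter, in either direction, and the expected step is a 1.2-fold lower number from compound 1 to compound 3 (0.07 log units; within the scatter). Compound 3 is accordingly estimated to give 50000 nM in this assay, with a range from 20000 nM to 150000 nM.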

Compound 3, half-maximal inhibitory concentration: 89600 nM
Estimate against measurement, compound 3: 1.8-fold (0.25 log units) below; low and high end bracket the measured number.
By their numbers in this assay, from the lowest: compounds 1, 2 and 3 (each within the scatter of the next).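

In this assay, replacing 4-fluorophenyl with 4-chlorophenyl gives a 1.5-fold higher number from compound 1 to compound 3 (0.18 log units; within the scatter). This is the only comparison shown in which a single place changes, and it shows that, at this position para to a large group, the two halogens cannot be told apart on this read-out, whereas the earlier pair, which differs in several places at once, could say nothing about this exchange. No measurement is available that would bear on the result beyond the read-out itself.

The compounds shown leave open whether a group other than a halogen at this place, such as an amine, a methoxy group or a carboxylic acid, would move the number beyond the scatter. They also leave open what the chloro and fluoro groups on the other aromatic ring each contribute, and whether any change to the chain or the far end of the core matters, since compound 2 differs from compound 1 in several places and no single-place step can be read for those groups.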